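Working notes on compound 4 against the measured set

This account rests on a few compounds, and the source may have more. Where it says the series, first, only, none or still open, it means among the compounds named here.

Compound 1 `COc1cccc(Cn2cnc3sc(-c4ccc5[nH]ncc5c4)cc3c2=O)c1` gives 20 nM in an assay on isolated protein for inhibition of Rho-associated protein kinase 1 (Homo sapiens), read by radiometric assay and 33P incorporation, with a stated time of 40 min, in the presence of a further agent that is not named here; on this read-out higher numbers stand for weaker inhibition and lower numbers for stronger inhibition. In this assay compound 2 `COc1cccc(Cn2cnc3sc(-c4cccnc4)cc3c2=O)c1` reaches only the assay limit, > 10000 nM, and so has no number of its own; it sits at the limit of > 10000 nM in this assay, at which 1 of the 3 values shown sits. Compound 3 `COc1cccc(Cn2cnc3sc(-c4ccnc(F)c4)cc3c2=O)c1` gives 1050 nM in this assay. The steps of an at least 500-fold higher number from compound 1 to compound 2 (2.69 log units; beyond the scatter) and a 53-fold higher number from compound 1 to compound 3 (1.72 log units; beyond the scatter) are both large. The step that bears on compound 4 `COc1cccc(Cn2cnc3sc(-c4ccnc(OC)c4)cc3c2=O)c1` is an at least 9.5-fold lower number from compound 2 to compound 3 (0.97 log units; beyond the scatter), since compound 4 carries 2-methoxypyridin-4-yl in place of pyridin-3-yl on an aromatic carbon, a change of the same kind that in compound 3 brought a number back within range. A step of similar size is therefore expected, an at least 5.0-fold lower number from compound 2 to compound 4 (0.69 log units; beyond the scatter), in this assay. The estimate for compound 4 is 2000 nM, expected to fall between 500 nM and 8000 nM.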

Compound 4, half-maximal inhibitory concentration: > 10000 nM
Compound 4 ended at the assay's limit (the forecaster's own chance of this, stated with the estimate: 15%); at least 5.0-fold (0.69 log units) between middle value and limit.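

In this assay, the readable number regained with 2-fluoropyridin-4-yl does not carry over to 2-methoxypyridin-4-yl: methoxy in place of fluoro gives an at least 9.5-fold higher number from compound 3 to compound 4 (0.97 log units; beyond the scatter), so a pyridin-4-yl ring at this position next to the ring sulfur does not by itself give a readable number. The distance to the 1H-indazol-5-yl group remains wide, with an at least 500-fold higher number from compound 1 to compound 4 (2.69 log units; beyond the scatter). Compound 2 and compound 4 share the assay limit, so the step between them cannot be read: the limit of > 10000 nM in this assay, at which 2 of the 4 values shown sit.

Still open, going by these compounds, is whether an amine or a chloro group in place of fluoro on the pyridine gives a readable number, and whether any such group comes close to compound 1.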